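The compounds below may be only part of what the source reports. "The series", "measured", "known", "first", "only" and "open" are said of these compounds alone.

In a physicochemical assay for solubility, in phosphate buffer, measured as kinetic solubility, at pH 7.4 (on this read-out lower numbers stand for lower solubility and higher numbers for higher solubility), compound 1 `Cc1ccc(C)c(-c2nc(CN3CCC(C(=O)NCCCN4C[C@H](C)C[C@H](C)C4)CC3)c(C)o2)c1` gives 56.1 ug/mL. Compound 2 `Cc1cccc(Cl)c1-c1nc(CN2CCC(C(=O)NCCCN3CCCC(C)C3)CC2)c(C)o1` gives 52.6 ug/mL in this assay, within the scatter of compound 1, so the two plain numbers shown stand together and neither can be set above the other. Compound 3 `Cc1ccc(-c2nc(CN3CCC(C(=O)NCCCN4C[C@H](C)C[C@H](C)C4)CC3)c(C)o2)c(C)c1` is recorded in this assay only as a limit, > 71 ug/mL. For the measured compounds named here, the one step of a single change among the measured compounds is an at least 1.2-fold higher number from compound 1 to compound 3 (0.10 log units; that floor lies within the scatter); it is bounded by the limit of > 71 ug/mL in this assay, at which 1 of the 3 values shown sits, and tells no more than that exchanging one dimethylphenyl for another did not lower the number.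

Compound 4 `COc1ccc(-c2nc(CN3CCC(C(=O)NCCCN4C[C@H](C)C[C@H](C)C4)CC3)c(C)o2)cc1OC` is not yet measured in this assay. Relative to compound 1 the change is 3,4-dimethoxyphenyl in place of 2,5-dimethylphenyl on an aromatic carbon. Going by the values given here, the only measured step that bears on it is the change of aryl substitution from compound 1 to compound 3, small and partly hidden by the limit; no measured pair covers a methoxy group, so the 3,4-dimethoxyphenyl has no direct precedent here. The expected step is therefore a 1.0-fold lower number from compound 1 to compound 4 (0.01 log units; within the scatter), with no assured direction beyond the scatter. Compound 4 is estimated at 55 ug/mL, with a range from 25 ug/mL to 110 ug/mL, and a fair chance that this assay returns a limit instead of a number.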

Compound 4, solubility: > 76 ug/mL
Compound 4: no number, only a limit; the forecaster's own chance of this, stated with the estimate: 35%; at least 1.3-fold (0.14 log units) between middle value and limit.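

In this assay, 3,4-dimethoxyphenyl in place of 2,5-dimethylphenyl, on the aromatic carbon next to the ring nitrogen and next to the ring oxygen, gives an at least 1.3-fold higher number from compound 1 to compound 4 (0.13 log units; that floor lies within the scatter). Compound 4 is recorded as > 76 ug/mL, which is a limit and not a number: the limit of > 76 ug/mL in this assay, at which 1 of the 4 values shown sits. For the compounds shown here, the one readable step before this covered only an exchange of one dimethylphenyl for another, whereas this step shows that the position also takes an aryl group carrying oxygen and hydrogen-bond acceptors without the number going lower than that of compound 1, although the floor of the step does not separate the two compounds beyond the scatter.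

Going by these compounds, the step from compound 3 to compound 4 cannot be read, as both values are limits, so the two aryl groups cannot be ranked and the true size of the gain over compound 1 stays unknown. Also open, on these data alone, is whether a plain number would be returned at this position for an aryl group bearing a carboxylic acid or a dimethylamino group, or for a saturated ring such as morpholine in place of the aryl group.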